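The source may report more compounds than this note shows. Statements on the series, on what has been measured and on what is new or still open speak of the compounds shown alone.

Compound 1 `CCCCN1NN=C(NC(=O)Nc2c(C(C)C)cccc2C(C)C)N1`: 92 nM
Compound 2 `COC(=O)CCCCCCCCCCN1NN=C(NC(=O)Nc2c(C(C)C)cccc2C(C)C)N1`: 4700 nM
Compound 3 `CCCCCCCCCCCCCc1nnc(NC(=O)Nc2c(C(C)C)cccc2C(C)C)s1`: 36 nM

Three compounds share a urea that joins a diisopropylphenyl ring to a small five-membered ring; they differ in that ring and in the chain attached to it. In an assay on microsomes from intestine for inhibition of acyl-CoA:cholesterol acyltransferase (Oryctolagus cuniculus) (on this read-out lower numbers stand for stronger inhibition and higher numbers for weaker inhibition), compound 3 gives the lowest number of the three. Compound 1 gives a higher number, and compound 2 a much higher one, both gaps beyond the scatter.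

Compound 4 `CCCCCCCCCc1nnc(NC(=O)Nc2c(C(C)C)cccc2C(C)C)s1` is compound 3 with its long chain cut short: hydrogen in place of butyl on a saturated chain carbon, nine bonds along the chain from an aromatic carbon. Among the compounds with values here, the one measured step on a single change is a 51-fold higher number from compound 1 to compound 2 (1.71 log units; beyond the scatter). That step adds a long chain ending in an ester to a ring nitrogen; it is not a shortening of a plain carbon chain on an aromatic carbon, so it bears on the present step only loosely, as a sign that chain length on this core can matter a lot. Within the data shown here, no measured pair varies a plain chain alone, and compound 1 and compound 3 differ in both ring and chain, so their values cannot separate the two.

With so little to go on, a modest weakening is expected: compound 4 is estimated at 70 nM, between 20 nM and 250 nM, a step of a 1.9-fold higher number from compound 3 to compound 4 (0.29 log units; within the scatter).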

Compound 4, half-maximal inhibitory concentration: 150 nM
Compound 4: the middle estimate sits 2.1-fold (0.33 log units) below what was measured; the range from low to high includes it.
By their numbers in this assay, from the lowest: compound 3; then compounds 1 and 4 (each within the scatter of the next); then compound 2.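

In this assay the shortening gives a 4.2-fold higher number from compound 3 to compound 4 (0.62 log units; beyond the scatter) and so shows that the outer end of this plain carbon chain counts, even though the change lies nine bonds along the chain from an aromatic carbon. Within the data shown here, this is the first pair here in which only a plain chain varies while the rest of the molecule stays the same, and the butyl that leaves holds carbon alone, with no ring, hydrogen-bond donor or hydrogen-bond acceptor. Nothing measured here explains why the shorter chain gives the higher number.

As far as these compounds go, two chain lengths on this core give a single step and no trend, so it stays open whether a longer chain would lower the number further or raise it again, and whether lengths in between change it gradually or abruptly. Also open, from the compounds shown here alone, are whether the same shortening would have a similar effect on the core of compound 1, and what an amine or a carboxylic acid at the end of the chain would do to the number.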